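A few compounds are considered here, and "the series" means these few. Any claim that something is new, unique, unknown or untested is made for them only; others in the source may bear on it.

Compound 2 `Cc1cc(Cl)cc(-c2ccnc3cc(CN4C(=O)CCC4=O)sc23)c1O[C@@H]1CCNC[C@@H]1C` is the starting point. In an assay on RKO cells for inhibition of ubiquitin carboxyl-terminal hydrolase 7 (Homo sapiens), read by a luciferase reporter, with a stated time of 18 h (a lower number here means that less compound is needed, a higher number that more compound is needed for the effect), compound 2 gives 150 nM, the second highest of the three numbers measured. Compound 1 `Cc1cc(Cl)cc(-c2ccnc3cc(CN4C(=O)C5CC5C4=O)sc23)c1O[C@@H]1CCNC[C@@H]1C` gives 170 nM and compound 3 `Cc1cc(Cl)cc(-c2ccnc3cc(CN4C(=O)C5C(C4=O)C5(C)C)sc23)c1NC1CCCNC1` gives 33 nM. For the measured compounds named here, the only step between compounds that differ in a single place, a 1.1-fold lower number from compound 1 to compound 2 (0.05 log units; within the scatter), concerns the imide ring and stays within the scatter. Compound 4 `Cc1cc(Cl)cc(-c2ccnc3cc(CN4C(=O)CCC4=O)sc23)c1CN1CCNC[C@@H]1C` differs from compound 2 elsewhere, on an aromatic carbon: (2-methylpiperazin-1-yl)methyl in place of (3-methylpiperidin-4-yl)oxy on an aromatic carbon. Going by the values given here, no measured step alters that part of the molecule alone; compound 3 differs from compound 2 in two places at once, so its lower number cannot be assigned to either change. Without a precedent, no step beyond the scatter is expected, no change at the digits printed from compound 2 to compound 4 (within the scatter). Compound 4 is therefore expected to give about 150 nM, within 50 nM to 500 nM.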

Compound 4, half-maximal effective concentration: 280 nM
The estimate for compound 4 lay 1.9-fold (0.27 log units) below the measured number; low and high end bracket the measured number.
By their numbers in this assay, from the lowest: compound 3; then compounds 2, 1 and 4 (each within the scatter of the next).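

In this assay, putting (2-methylpiperazin-1-yl)methyl in place of (3-methylpiperidin-4-yl)oxy on this aromatic carbon gives a 1.9-fold higher number from compound 2 to compound 4 (0.27 log units; within the scatter). This position therefore accepts a second ring-bearing group of the same heavy-atom count, with a different link to the aromatic ring and an added ring nitrogen, with no step beyond the scatter. No measurement shown explains this result. From the compounds shown here alone, what the link and the ring each contribute on their own stays open, as does the effect of a carboxylic acid or a longer chain on this aromatic carbon.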